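Chloro to hydrogen on the shared core: compound 4

The source may report more compounds than this note shows. Statements on the series, on what has been measured and on what is new or still open speak of the compounds shown alone.

Compound 1 `Nc1nc(Cl)c2ncn(Cc3ccc(CCl)cc3)c2n1` gives 3390 nM in a functional assay on SW-620 cells (Homo sapiens) for cytotoxicity, read by sulforhodamine B assay, with a stated time of 48 h (on this read-out higher numbers stand for weaker inhibition of growth and lower numbers for stronger inhibition of growth), and compound 3 `ClCc1ccc(Cn2cnc3c(Cl)nc(Cl)nc32)cc1` gives 3800 nM; the two differ by a 1.1-fold higher number from compound 1 to compound 3 (0.05 log units; within the scatter). Compound 2 `ClCc1cccc(Cn2cnc3nc(Cl)nc(Cl)c32)c1` gives 410 nM in this assay, the lowest of the three numbers, separated from compound 1 and from compound 3 by more than the scatter. Compound 4 `ClCc1cccc(Cn2cnc3ncnc(Cl)c32)c1` awaits measurement and differs from compound 2 by hydrogen in place of chloro on an aromatic carbon. Among the measured compounds shown here, the step from compound 1 to compound 3 is the one measured change on that aromatic carbon, and it stayed within the scatter, so no step beyond the scatter is expected for compound 4 in this assay, in either direction. Compound 4 is estimated at 550 nM, with a range from 200 nM to 1600 nM. The expected step is a 1.3-fold higher number from compound 2 to compound 4 (0.13 log units; within the scatter).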

Compound 4, concentration for 50% growth inhibition: 15100 nM
Compound 4: the middle estimate sits 27-fold (1.44 log units) below what was measured, outside the stated range (above it).
By their numbers in this assay, from the lowest: compound 2; then compounds 1 and 3 (each within the scatter of the next); then compound 4.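

In this assay, the aromatic carbon between two ring nitrogen atoms proves sensitive to its substituent: hydrogen in place of chloro gives a 37-fold higher number from compound 2 to compound 4 (1.57 log units; beyond the scatter). The earlier exchange on this carbon, chloro in place of amino, gives a 1.1-fold higher number from compound 1 to compound 3 (0.05 log units; within the scatter), so a substituent change here need not leave the number within the scatter, although those two compounds carry a different arrangement of the rest of the molecule. No available evidence explains the size of this step.

Open, as far as these compounds go, is whether a bromo or methoxy group on this carbon would keep the number of compound 2. Also open, from the compounds shown here alone, is whether hydrogen in place of chloro here would give a comparable step in compound 3.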